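This account rests on a few compounds, and the source may have more. Where it says the series, first, only, none or still open, it means among the compounds named here.

Compound 1 `COc1ccc(-c2cc(=O)c3c(OC)cc(OC)cc3n2S(=O)(=O)c2ccc([N+](=O)[O-])cc2)cc1` and compound 2 `COc1ccc(-c2cc(=O)c3c(OC)cc(OC)cc3n2S(=O)(=O)c2ccc(F)cc2)cc1` share a core and were tested in a functional assay on HepG2 cells (Homo sapiens) for antiproliferative activity, with a stated time of 72 h; on this read-out lower numbers stand for an effect already at smaller amounts and higher numbers for an effect only at larger amounts of compound. In this assay compound 1 reaches only a limit of > 29300 nM, not a number. Compound 2 likewise gives only a limit of > 65500 nM in this assay. The change between them is fluoro in place of nitro on an aromatic carbon and the step it made is a step that the two limits leave unreadable from compound 1 to compound 2; its size cannot be read because the limit of > 29300 nM in this assay, at which 1 of the 3 values shown sits, and the limit of > 65500 nM in this assay, at which 1 of the 3 values shown sits, are both limits rather than values.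

Compound 3 `COc1cc(OC)c2c(=O)cc(C(=O)Nc3ccc(Oc4ccc([N+](=O)[O-])cc4)cc3)[nH]c2c1` rests on a different core, and the difference between the two cores is not broken down here. In this assay compound 3 also stops at a limit of > 22900 nM, so that the limit of > 22900 nM in this assay, at which 1 of the 3 values shown sits, is again a limit and not a number.

Compound 4 `COc1cc(OC)c2c(=O)cc(C(=O)Nc3ccc(Oc4ccc(F)cc4)cc3)[nH]c2c1` is not yet measured. It differs from compound 3 by fluoro in place of nitro on an aromatic carbon, the same change as that from compound 1 to compound 2, at a place that reads the same in both pairs. Since the earlier step is unreadable and compound 3 itself gave only a limit, compound 4 is expected to sit at a similar level, and the step that the limit leaves unreadable from compound 3 to compound 4 is estimated to be small. In this assay compound 4 is expected to give about 40000 nM, between 15000 nM and 150000 nM, most likely reported again only as a limit.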

Compound 4, half-maximal effective concentration: > 50000 nM
Compound 4 gave a limit, no number (the forecaster's own chance of this, stated with the estimate: 80%); at least 1.2-fold (0.09 log units) between middle value and limit.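

Compound 3 and compound 4 both stop at limits in this assay, and the step from nitro to fluoro cannot be read for this pair, just as it could not be read between compound 1 and compound 2. The compounds shown leave open how large a step fluoro in place of nitro makes on either core, and at what concentration any of the four compounds would reach a half-maximal effect.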